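The source may hold more compounds than are shown below. What is called first, only, known or untested is meant among the compounds shown, and "the series" means these compounds.

Measured so far:
- compound 1, `Cc1ccc(Nc2cc(C)nc(SCc3nc4ccccc4[nH]3)n2)cc1`: 57300 nM
- compound 2, `Cc1cc(NC(C)C)nc(SCc2nc3ccccc3[nH]2)n1`: > 100000 nM

Both numbers come from a functional assay on ECa-109 cells (Homo sapiens) for cytotoxicity, read by MTT assay, with a stated time of 72 h; on this read-out lower numbers stand for stronger inhibition and higher numbers for weaker inhibition. Compound 1 gives 57300 nM in this assay. For compound 2 this assay reports only a limit, > 100000 nM, which is the limit of > 100000 nM in this assay, at which 1 of the 2 values shown sits. Within the data shown here, the single measured step, an at least 1.7-fold higher number from compound 1 to compound 2 (0.24 log units; that floor lies within the scatter), swapped 4-methylphenyl for isopropyl and the number moved upward to that limit, so the floor of the step sits within the scatter and its true size is not known.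

Compound 3, `Cc1cc(Nc2ccc(Br)cc2)nc(SCc2nc3ccccc3[nH]2)n1`, makes the change in the opposite sense: 4-bromophenyl in place of isopropyl on a nitrogen on an aromatic ring. Among the measured compounds shown here, because the only measured step is an at least 1.7-fold higher number from compound 1 to compound 2 (0.24 log units; that floor lies within the scatter), the return of a six-membered aromatic ring on that nitrogen is expected to bring the number back down, roughly to where compound 1 sits, as an estimated step of an at least 2.0-fold lower number from compound 2 to compound 3 (0.30 log units; that floor lies within the scatter). Compound 3 is therefore estimated at 50000 nM, with a range from 15000 nM to 100000 nM.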

Compound 3, half-maximal inhibitory concentration: 42900 nM
The estimate for compound 3 lay 1.2-fold (0.07 log units) above the measured number; measured number inside the range.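

Putting 4-bromophenyl in place of isopropyl on the nitrogen gives, in this assay, an at least 2.3-fold lower number from compound 2 to compound 3 (0.36 log units; beyond the scatter), so unlike the earlier step, this one clears the scatter and ties the aromatic ring at this place to a lower number. Compound 2 is known only as a limit, which makes this step a floor and leaves its true size unknown: the limit of > 100000 nM in this assay, at which 1 of the 3 values shown sits.

On the ring itself, bromo in place of methyl on an aromatic carbon gives a 1.3-fold lower number from compound 1 to compound 3 (0.13 log units; within the scatter), so these two values cannot be told apart and this swap shows no effect here.

From the compounds shown here alone, it remains open whether a cyclohexyl group, a saturated ring, on that nitrogen would track 4-bromophenyl or isopropyl. Going by these compounds, it is also open whether a hydroxyl or an amine in place of the bromo would move the number beyond the scatter.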